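A few compounds are considered here, and "the series" means these few. Any claim that something is new, unique, unknown or untested is made for them only; others in the source may bear on it.

In a functional assay on LoVo cells (Homo sapiens) for inhibition, read by MTT assay, with a stated time of 24 h (a higher number here means a weaker inhibitor, a lower number a stronger inhibitor), three compounds sharing one core have been measured. Compound 1 `Cc1ccccc1-n1cc(CN2C(=O)C[C@@H]3CC[C@@]2(C)C3(C)C)nn1` gives 80 nM. Compound 2 `CC1(C)[C@H]2CC[C@]1(C)N(Cc1cn(-c3ccccc3)nn1)C(=O)C2` gives 50 nM, and compound 3 `CC1(C)[C@H]2CC[C@]1(C)N(Cc1cn(-c3ccccc3Br)nn1)C(=O)C2` gives 60 nM. Compound 1 is separated from the other two only by steps that fall within the scatter: a 1.6-fold lower number from compound 1 to compound 2 (0.20 log units; within the scatter) and a 1.3-fold lower number from compound 1 to compound 3 (0.12 log units; within the scatter), while a 1.2-fold higher number from compound 2 to compound 3 (0.08 log units; within the scatter) likewise stays within it. Nothing among these three numbers can therefore be called a real difference.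

Compound 4 `CC1(C)[C@H]2CC[C@]1(C)N(Cc1cn(-c3cccc(F)c3)nn1)C(=O)C2` has not yet been measured in this assay. It differs from compound 1 in one place: 3-fluorophenyl in place of 2-methylphenyl on an aromatic nitrogen. For the measured compounds named here, of the measured steps, the one from compound 1 to compound 2 bears most directly on this change, since it also removes the methyl from the phenyl on the aromatic nitrogen; the steps to compound 3 show that placing a bromo on that ring instead changes nothing beyond the scatter either. Going by the values given here, no measured compound carries a fluorine, and none carries a group at the 3-position of that phenyl, so that part of the change has no precedent here.

Compound 4 is therefore expected to sit close to its neighbours, with a 1.5-fold lower number from compound 1 to compound 4 (0.16 log units; within the scatter) as the estimated step. The estimate for compound 4 is 55 nM, with a range from 25 nM to 120 nM.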

Compound 4, half-maximal inhibitory concentration: 90 nM
Compound 4: the middle estimate sits 1.6-fold (0.21 log units) below what was measured; measured number inside the range.
By their numbers in this assay, from the lowest: compounds 2, 3, 1 and 4 (each within the scatter of the next).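

In this assay, 3-fluorophenyl on the aromatic nitrogen leaves the number within the scatter of all three earlier compounds: replacing 2-methylphenyl gives a small step (a 1.1-fold higher number from compound 1 to compound 4 (0.05 log units; within the scatter)), replacing 2-bromophenyl gives another (a 1.5-fold higher number from compound 3 to compound 4 (0.18 log units; within the scatter)), and fluoro in place of hydrogen on the aromatic carbon gives the largest of the three, which still does not pass the scatter (a 1.8-fold higher number from compound 2 to compound 4 (0.26 log units; within the scatter)). The earlier compounds shown here had covered only phenyl, 2-methylphenyl and 2-bromophenyl at this position, so compound 4 adds both a fluorine and a different place on the phenyl without a readable change. No measured evidence is available to explain these numbers.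

The compounds shown leave open whether the numbers would stay this close with an amine, a carboxylic acid or a longer chain such as propyl on the phenyl. No compound shown carries another group where compound 4 carries its fluoro, so the effect of the group and the effect of its place on the ring cannot be told apart.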